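Triazolylmethyl Spirooxindoles Tested on Colon Carcinoma Cells

The source may hold more compounds than are shown below. What is called first, only, known or untested is meant among the compounds shown, and "the series" means these compounds.

Compound 1 `N#CC1=C(N)Oc2c(N)cc3nc4ccccc4nc3c2C12C(=O)N(Cc1cnnn1-c1ccc(Cl)cc1)c1ccccc12`, compound 2 `N#CC1=C(N)Oc2c(N)cc3nc4ccccc4nc3c2C12C(=O)N(Cc1cnnn1-c1ccc([N+](=O)[O-])cc1)c1ccccc12` and compound 3 `N#CC1=C(N)Oc2c(N)cc3nc4ccccc4nc3c2C12C(=O)N(Cc1cnnn1-c1ccc([N+](=O)[O-])cc1[N+](=O)[O-])c1ccccc12` share one core and differ only in the aryl group on the triazole nitrogen. In a functional assay on HCT-116 cells (Homo sapiens) for antiproliferative activity, read by MTT assay, with a stated time of 48 h (a lower number here means a stronger inhibitor, a higher number a weaker inhibitor), compound 1 gives > 50000 nM, a limit of the assay and not a number. Compound 2 likewise gives only a limit, > 50000 nM. For the measured compounds named here, compound 3 gives 23900 nM, the sole number of the three. The change from compound 2 to compound 3 is nitro in place of hydrogen on an aromatic carbon, and the step is an at least 2.0-fold lower number from compound 2 to compound 3 (0.32 log units; beyond the scatter). The change from compound 2 to compound 1 is chloro in place of nitro on an aromatic carbon; its step is a step that the two limits leave unreadable from compound 2 to compound 1 because of the limit of > 50000 nM in this assay, at which 2 of the 3 values shown sit. Compound 4 `N#CC1=C(N)Oc2c(N)cc3nc4ccccc4nc3c2C12C(=O)N(Cc1cnnn1-c1ccc(Cl)cc1[N+](=O)[O-])c1ccccc12` is not yet measured. It carries the same kind of change, (chloro in place of nitro on an aromatic carbon), though here the place is also meta to a nitro group. The earlier step of this kind offers no readable size, so the expectation for compound 4 rests mainly on the weak values throughout the series. Compound 4 is expected to give about 40000 nM, between 15000 nM and 100000 nM. The estimated step is a 1.7-fold higher number from compound 3 to compound 4 (0.22 log units; within the scatter).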

Compound 4, half-maximal inhibitory concentration: 28700 nM
Beside the measured number, compound 4's estimate is 1.4-fold (0.14 log units) above it, and the stated range covers the measured number.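

Chloro in place of nitro gives a 1.2-fold higher number from compound 3 to compound 4 (0.08 log units; within the scatter) in this assay, and 4-chloro-2-nitrophenyl in place of 4-nitrophenyl gives an at least 1.7-fold lower number from compound 2 to compound 4 (0.24 log units; that floor lies within the scatter). Nitro in place of hydrogen gives an at least 1.7-fold lower number from compound 1 to compound 4 (0.24 log units; that floor lies within the scatter), a step that starts from a limit of the assay and so gives only a floor. Both cores thus give a readable number once this nitro is present, but this does not show that the step has the same size on each: the same change on two cores in this assay, an at least 2.0-fold lower number (0.32 log units; beyond the scatter) from compound 2 to compound 3 and an at least 1.7-fold lower number (0.24 log units; that floor lies within the scatter) from compound 1 to compound 4; the limit leaves it open whether they differ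

The compounds shown leave open whether an amine or a carboxylic acid on the same aryl ring would also give a readable number. The true size of each step from compound 1 or compound 2 also stays unknown: the limit of > 50000 nM in this assay, at which 2 of the 4 values shown sit.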